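The compounds below may be only part of what the source reports. "The series", "measured", "known", "first", "only" and "open" are said of these compounds alone.

Measured compounds in a functional assay on P388 cells (Mus musculus) for inhibition, read by MTT assay; on this read-out higher numbers stand for weaker inhibition and lower numbers for stronger inhibition:
compound 1 `OC1C#CCCCCC#C/C1=C\c1ccccc1` gives 25000 nM
compound 2 `OC1C#CCCCCC#C/C1=C\c1ccc2ccccc2c1` gives 3600 nM
compound 3 `COc1ccc(/C=C2\C#CCCCCC#CC2O)cc1` gives 5800 nM

Among these three, compound 1 gives the highest number; compound 3 sits nearest to it and compound 2 furthest away. Among the compounds with values here, the only step measured between two compounds, a 4.3-fold lower number from compound 1 to compound 3 (0.63 log units; beyond the scatter), alters the aromatic part, not the alcohol. Compound 4 `CC(=O)OC1C#CCCCCC#C/C1=C\c1ccccc1` differs from compound 1 by acetyl in place of hydrogen on an oxygen on a saturated carbon. Within the data shown here, no measured step touches this oxygen, so no direct precedent exists; the one known step is of modest size. For compound 4 the expected step is a 1.3-fold lower number from compound 1 to compound 4 (0.10 log units; within the scatter), most likely within the scatter. Compound 4 is accordingly estimated at 20000 nM, with a range from 6000 nM to 60000 nM.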

Compound 4, half-maximal inhibitory concentration: 48000 nM
For compound 4 the middle estimate is 2.4-fold (0.38 log units) below the measured one; the measured number falls inside the stated range.
By their numbers in this assay, from the lowest: compounds 2 and 3 (each within the scatter of the next); then compounds 1 and 4 (each within the scatter of the next).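

Within the data shown here, replacing the hydrogen on the oxygen with acetyl, hydroxy to acetoxy, is the first change measured at this position. In this assay it gives a 1.9-fold higher number from compound 1 to compound 4 (0.28 log units; within the scatter), so on the core of compound 1 this oxygen carries an acetyl with no difference that can be told apart from repeat-measurement noise. The data shown offer no measurement that could explain this result.

Going by these compounds, whether a methyl ether, a benzoate or an amine in place of the hydroxy would also stay this close remains open. So does whether acetyl on the oxygen of compound 2 or compound 3 would behave the same way.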